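The source may hold more compounds than are shown below. What is called first, only, known or untested is meant among the compounds shown, and "the series" means these compounds.

Measured compounds:
Compound 1 `CC(C)OC(=O)N1CCC(n2ncc3cc(-c4ccc(S(C)(=O)=O)nc4)ncc32)CC1` — in a functional assay on HEK293 cells for agonist activity at Glucose-dependent insulinotropic receptor (Homo sapiens), read by cAMP accumulation, with a stated time of 30 min (on this read-out lower numbers stand for an effect already at smaller amounts and higher numbers for an effect only at larger amounts of compound), compound 1 gives 197 nM
Compound 2 `CC(C)OC(=O)N1CCC(n2ncc3cc(-c4ccc(S(C)(=O)=O)cc4F)ncc32)CC1` — in this assay compound 2 gives 27 nM

Of the two numbers recorded, compound 2 has the lower one, and compound 1 gives the higher number; the gap between the two lies beyond the usual scatter of this assay, so compound 2 stands as the more potent of the pair. These two differ in more than one place, so no single step can be read from them.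

Compound 3 `CC(C)OC(=O)N1CCC(n2ncc3cc(-c4ccc(C(N)=O)cc4F)ncc32)CC1` has not yet been measured. It is derived from compound 2 by one change: carbamoyl in place of methylsulfonyl on an aromatic carbon, that is, a carbamoyl in place of a methylsulfonyl on an aromatic carbon. Going by the values given here, no measured pair in this set shows what such a swap does here, so the direction and size of the step are open. The account expects a modest step, not clearly beyond the scatter in either direction, since the remainder of compound 2 is kept intact. The expected step is a 1.5-fold higher number from compound 2 to compound 3 (0.17 log units; within the scatter). For compound 3 in this assay the estimate is 40 nM, with a range from 12 nM to 130 nM.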

Compound 3, half-maximal effective concentration: 97 nM
The estimate for compound 3 lay 2.4-fold (0.38 log units) below the measured number, and the stated range covers the measured number.
By their numbers in this assay, from the lowest: compound 2; then compound 3; then compound 1.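

In this assay, going by these compounds alone, carbamoyl in place of methylsulfonyl on this aromatic carbon, meta to a fluoro group and para to a large group, brings a 3.6-fold higher number from compound 2 to compound 3 (0.56 log units; beyond the scatter) and gives the first direct reading at this position: activity in the nanomolar range does not depend on the methylsulfonyl group, but carbamoyl does not match it on this ring. The 4-carbamoyl-2-fluorophenyl group in place of the 6-(methylsulfonyl)pyridin-3-yl group shows a 2.0-fold lower number from compound 1 to compound 3 (0.31 log units; beyond the scatter) and so places the carbamoyl compound between the two methylsulfonyl compounds, which shows that the choice of group at this position does not alone settle the order of the three. Nothing at hand accounts for either step.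

The step between compound 1 and compound 2 cannot be read, so what the fluoro group and the ring nitrogen each contribute stays apart from these numbers. Also open, as far as these compounds go, is how other groups on this aromatic carbon would compare, such as a nitrile, a carboxylic acid or an N-methylcarbamoyl group.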